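Ether substituent change on the core of compound 1

The source may hold more compounds than are shown below. What is called first, only, known or untested is meant among the compounds shown, and "the series" means these compounds.

Measured compounds in a functional assay on HEK293 cells for agonist activity at G-protein coupled receptor 39 (Homo sapiens), read by scintillation proximity assay and inositol phosphate accumulation, with a stated time of 75 min, in the presence of a further agent that is not named here; a higher number here means that more compound is needed for the effect, a lower number that less compound is needed:
compound 1 `Cc1nn(-c2ncnc3nc[nH]c23)c2c1C(OC1CCCC1)CC(=O)N2` gives 2 nM
compound 2 `Cc1nn(-c2ncnc3nc[nH]c23)c2c1C(C(=O)NCc1ccc(F)cc1)CC(=O)N2` gives 4 nM
compound 3 `C=CCN1c2c(n(C)c(=O)n(C)c2=O)NC1N/N=C/c1ccc(O)cc1O` gives 340 nM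

Compound 1 has the lowest of the three numbers. Its nearest neighbour is compound 2, whose number is higher by an amount that lies within the usual scatter, so no order between compound 1 and compound 2 can be read from these two values. Compound 3, built on a different core, stands far beyond the scatter from both.

The unmeasured compound 4 `COc1ccc(CCOC2CC(=O)Nc3c2c(C)nn3-c2ncnc3nc[nH]c23)cc1` keeps the core of compound 1 and is changed at one place:
2-(4-methoxyphenyl)ethyl in place of cyclopentyl on an oxygen on a saturated carbon

Going by the values given here, no step between measured compounds bears on this change. Compound 2 shows that the position carrying the substituent tolerates a group with an aromatic ring while keeping a value close to that of compound 1, so a large loss is not anticipated. The step of a 2.5-fold higher number from compound 1 to compound 4 (0.40 log units; beyond the scatter) is expected to be modest, if anything towards a slightly higher number, and quite possibly within the scatter. For compound 4 the estimate is 5 nM, with a range from 1.5 nM to 20 nM.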

Compound 4, half-maximal effective concentration: 2 nM
For compound 4 the middle estimate is 2.5-fold (0.40 log units) above the measured one, within the range that was stated.
By their numbers in this assay, from the lowest: compounds 1, 4 and 2 (each within the scatter of the next); then compound 3.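

In this assay the swap of cyclopentyl for 2-(4-methoxyphenyl)ethyl on an oxygen on a saturated carbon gives no change at the digits printed from compound 1 to compound 4 (within the scatter) and so leaves the two compounds indistinguishable, even though the substituent goes from 5 to 10 heavy atoms, a five-membered non-aromatic ring gives way to a six-membered aromatic ring, and a hydrogen-bond acceptor enters. Going by these compounds alone, this is the first one-place comparison at this ether oxygen, and it shows directly that the value in this assay does not separate these two quite different substituents on the shared core. No measurement is available that accounts for this result.

The compounds shown leave open whether a plain 2-phenylethyl, a longer chain, or a chain ending in an amine or a carboxylic acid on this oxygen would also stay within the scatter of compound 1. They also leave open what part, if any, the methoxy group of compound 4 plays, and how small a group on this oxygen, such as methyl, could be before the value moves.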